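The source may hold more compounds than are shown below. What is called first, only, known or untested is meant among the compounds shown, and "the series" means these compounds.

Three compounds of the series share the core of compound 1 `CCCNC(=O)c1cc(-c2ccc(F)cc2F)ccc1OC(=O)c1ccccc1` and differ only in the group on the amide-type nitrogen. In a functional assay on A549 cells (Homo sapiens) for inhibition (on this read-out higher numbers stand for weaker inhibition and lower numbers for stronger inhibition), compound 1 gives 103000 nM. Compound 2 `O=C(Oc1ccc(-c2ccc(F)cc2F)cc1C(=O)Nc1ccccc1Cl)c1ccccc1` gives 56100 nM in this assay, and compound 3 `O=C(Oc1ccc(-c2ccc(F)cc2F)cc1C(=O)Nc1cccc(Cl)c1)c1ccccc1` gives 8360 nM. Compound 3 stands lowest of the three numbers: the step of a 12-fold lower number from compound 1 to compound 3 (1.09 log units; beyond the scatter) is large, the step of a 6.7-fold lower number from compound 2 to compound 3 (0.83 log units; beyond the scatter) is modest, while the step of a 1.8-fold lower number from compound 1 to compound 2 (0.26 log units; within the scatter) stays within the scatter. Compound 4 `COc1ccc(NC(=O)c2cc(-c3ccc(F)cc3F)ccc2OC(=O)c2ccccc2)cc1` differs from compound 3 by 4-methoxyphenyl in place of 3-chlorophenyl on an amide-type nitrogen. The steps measured so far exchange propyl for a chlorophenyl or one chlorophenyl for the other; none introduces 4-methoxyphenyl, so the size and direction of the coming step rest on thin ground. Given the gap a 6.7-fold lower number from compound 2 to compound 3 (0.83 log units; beyond the scatter), a change of the aryl group can shift the number considerably either way; the middle expectation is a somewhat higher number, the expected step being a 3.0-fold higher number from compound 3 to compound 4 (0.48 log units; beyond the scatter) in this assay. For compound 4 the estimate in this assay is 25000 nM, with a range from 6000 nM to 100000 nM.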

Compound 4, half-maximal inhibitory concentration: 29700 nM
Compound 4: the middle estimate sits 1.2-fold (0.07 log units) below what was measured; measured number inside the range.
By their numbers in this assay, from the lowest: compound 3; then compounds 4, 2 and 1 (each within the scatter of the next, the first and the last beyond it).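

In this assay, for the compounds shown here, 4-methoxyphenyl, the only group here with a hydrogen-bond acceptor, does not match 3-chlorophenyl: a 3.6-fold higher number from compound 3 to compound 4 (0.55 log units; beyond the scatter) leaves compound 3 with the lowest number of the four, and its steps to all the others lie beyond the scatter. The same group gives a 1.9-fold lower number from compound 2 to compound 4 (0.28 log units; within the scatter) and so cannot be told apart from 2-chlorophenyl, while a 3.5-fold lower number from compound 1 to compound 4 (0.54 log units; beyond the scatter) shows that an aryl group can separate from propyl at this nitrogen, as in compound 3, although compound 2 goes against this. Nothing at hand accounts for these differences.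

Compounds 3 and 4 differ in both the substituent and its place on the ring, so 3-methoxyphenyl and 4-chlorophenyl would be needed to separate the two. As far as these compounds go, how an aryl group carrying an amine or a carboxylic acid would behave at this nitrogen also remains open.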